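From 3-Chlorobenzyl to 4-Methylbenzyl: One Small Swap

The compounds below may be only part of what the source reports. "The series", "measured", "known", "first", "only" and "open" are said of these compounds alone.

Of the compounds shown here, two that share one core have numbers so far in a functional assay on NCI-H460 cells (Homo sapiens) for cytotoxicity, read by MTT assay, with a stated time of 72 h (on this read-out lower numbers stand for stronger inhibition and higher numbers for weaker inhibition), and they sit apart. Compound 1 (`CCN(CC)Cc1ccc2nc(NC(=O)N/N=C/c3cn(Cc4ccc(C(C)(C)C)cc4)c4ccccc34)sc2c1`) stands at 1670 nM while compound 2 (`CCN(CC)Cc1ccc2nc(NC(=O)N/N=C/c3cn(Cc4cccc(Cl)c4)c4ccccc34)sc2c1`) stands at 220 nM and holds the lower of the two numbers, the stronger result.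

The unmeasured compound 3 (`CCN(CC)Cc1ccc2nc(NC(=O)N/N=C/c3cn(Cc4ccc(C)cc4)c4ccccc34)sc2c1`) differs from compound 2 in one group. The counted difference is 4-methylphenyl in place of 3-chlorophenyl on a saturated chain carbon bound to an aromatic nitrogen and it amounts to 4-methylphenyl in place of 3-chlorophenyl on a saturated chain carbon bound to an aromatic nitrogen.

For the measured compounds named here, only one measured step touches this place. It is a 7.6-fold lower number from compound 1 to compound 2 (0.88 log units; beyond the scatter) and it came with 3-chlorophenyl in place of 4-(tert-butyl)phenyl. The 4-methylphenyl of compound 3 shares its numbering with the 4-(tert-butyl)phenyl of compound 1 (1670 nM), though one step is thin evidence for any rule. A rise is therefore expected, smaller than that modest step, and the estimated move is a 2.3-fold higher number from compound 2 to compound 3 (0.36 log units; beyond the scatter) on this reasoning. For compound 3 the estimated value is 500 nM with an expected range of 170 nM to 1500 nM for the coming measurement.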

Compound 3, half-maximal inhibitory concentration: 320 nM
Estimate against measurement, compound 3: 1.6-fold (0.19 log units) above, within the range that was stated.
By their numbers in this assay, from the lowest: compounds 2 and 3 (each within the scatter of the next); then compound 1.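

In this assay, the swap shows a 1.5-fold higher number from compound 2 to compound 3 (0.16 log units; within the scatter) and so leaves compound 2 and compound 3 indistinguishable, even though the ring group changes both its substituent and its numbering. The comparison that keeps the numbering fixed behaves differently: methyl in place of tert-butyl on an aromatic carbon gives a 5.2-fold lower number from compound 1 to compound 3 (0.72 log units; beyond the scatter) and is a change beyond the scatter. Among these three compounds, then, the weaker number of compound 1 goes with its tert-butyl group rather than with the 4-numbering it shares with compound 3, and no measurement offered here says why the numbers fall this way.

As far as these compounds go, since 3-chlorobenzyl and 4-methylbenzyl differ in both substituent and numbering, the effect of each alone remains open, and a 4-chlorobenzyl or 3-methylbenzyl group would separate the two. Also open, from the compounds shown here alone, is how the number would respond to a plain benzyl with no ring substituent, or to a substituent of a different kind on this ring, such as a methoxy group or an amine.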